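Replacing the ring-nitrogen acyl group in a rat half-life series

The compounds below may be only part of what the source reports. "The series", "measured", "known", "first", "only" and "open" are said of these compounds alone.

Compound 1 `COc1cc(C2CCN(C)CC2)ccc1Nc1ncc2ccc(-c3ccccc3OC)n2n1` — 1.4 h
Compound 2 `COc1cc(C2CCN(C(=O)C3CCN3)CC2)ccc1Nc1ncc2ccc(-c3ccccc3OC)n2n1` — 2.5 h

Of the compounds shown here, two built on a shared core have been tested in an in vivo ADME assay on the whole organism (strain Sprague-Dawley) for metabolic stability, with Rattus norvegicus as the target, at a dose of 1 mg/kg by the intravenous route; a lower number here means that the compound disappears faster, a higher number that the compound lasts longer. Compound 1 gives 1.4 h in this assay, and compound 2 gives 2.5 h. Going by the values given here, the only step between them, a 1.8-fold higher number from compound 1 to compound 2 (0.25 log units; within the scatter), exchanges one group on the amine nitrogen of the piperidine ring. Compound 2 stands highest of the two numbers, but its nearest neighbour, compound 1, lies within the scatter of it, so no order can be read from these two values.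

Compound 3 `COc1cc(C2CCN(CC(N)=O)CC2)ccc1Nc1ncc2ccc(-c3ccccc3OC)n2n1` has not yet been measured in this assay. Its difference from compound 2 is carbamoylmethyl in place of (azetidin-2-yl)carbonyl on an amine nitrogen in a ring. Among the compounds with values here, the single measured step that bears on this site, a 1.8-fold higher number from compound 1 to compound 2 (0.25 log units; within the scatter), also altered the group on that same ring nitrogen and stayed within the scatter. On that basis no step beyond the scatter is expected in this assay, in either direction, and the change a 1.3-fold lower number from compound 2 to compound 3 (0.10 log units; within the scatter) is estimated to be small. Compound 3 is therefore expected to give about 2 h, within a range of 1 h to 4 h.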

Compound 3, half-life: 3.4 h
Compound 3: the middle estimate sits 1.7-fold (0.23 log units) below what was measured, within the range that was stated.
By their numbers in this assay, from the lowest: compounds 1, 2 and 3 (each within the scatter of the next, the first and the last beyond it).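

In this assay, the amine nitrogen in the ring now gives its first step that stands clear of the scatter: carbamoyl in place of hydrogen on the saturated chain carbon bound to that nitrogen gives a 2.4-fold higher number from compound 1 to compound 3 (0.39 log units; beyond the scatter), a modest step. Carbamoylmethyl in place of (azetidin-2-yl)carbonyl gives a 1.4-fold higher number from compound 2 to compound 3 (0.13 log units; within the scatter), so these two groups cannot be told apart in this read-out, even though the group that leaves holds a four-membered ring and the group that enters has no ring. No measurement at hand accounts for either step.

On these data alone, how a carboxylic acid, a nitrile or a longer chain ending in the same carbamoyl group would behave on this ring nitrogen remains open, and so does whether the terminal amide nitrogen matters to the step from the methyl group. All three compounds share one core and differ only at this nitrogen, so the compounds shown also leave open whether the same step would appear with any other part of the structure changed.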